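A few compounds are considered here, and "the series" means these few. Any claim that something is new, unique, unknown or untested is made for them only; others in the source may bear on it.

Measured compounds in an assay on Sf9 cells for inhibition of tyrosine-protein kinase receptor UFO (Homo sapiens), read by luminescence and ADP-Glo; on this read-out higher numbers stand for weaker inhibition and lower numbers for stronger inhibition:
Compound 1 `COc1ccc(Nc2ncc(C(F)(F)F)c(N3Cc4cccc(N(C)S(C)(=O)=O)c4C3)n2)cc1C(F)(F)F` gives > 20000 nM, a limit of the assay.
Compound 2 `CC(=O)N1CCN(c2ccc(Nc3ncc(C(F)(F)F)c(N4Cc5cccc(N(C)S(C)(=O)=O)c5C4)n3)cc2)CC1` gives < 0.5 nM, a limit of the assay.
Compound 3 `Cc1ccc(Nc2ncc(C(F)(F)F)c(N3Cc4cccc(N(C)S(C)(=O)=O)c4C3)n2)cc1C` gives > 20000 nM, a limit of the assay.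

Compound 1 stands at the upper limit; no number is known for it, and both other values shown are limits as well. Compound 4 `COc1ccc(C(F)(F)F)cc1Nc1ncc(C(F)(F)F)c(N2Cc3cccc(N(C)S(C)(=O)=O)c3C2)n1` differs from compound 1 by 2-methoxy-5-(trifluoromethyl)phenyl in place of 4-methoxy-3-(trifluoromethyl)phenyl on a nitrogen on an aromatic ring. Going by the values given here, the only measured step at this position, a step that the two limits leave unreadable from compound 1 to compound 3, is unreadable since both ends sit at limits, and no measured pair changes the group in this way. Compound 2 shows that a different group on this nitrogen can reach the lower limit, so the range is wide. Because compound 1 sits at the limit of > 20000 nM in this assay, at which 2 of the 3 values shown sit, the expectation for compound 4 is a similar limit, with large uncertainty. Compound 4 is therefore expected to give 20000 nM, within 500 nM to 40000 nM. The expected step is a number no higher from compound 1 to compound 4 (the limit leaves the size open).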

Compound 4, half-maximal inhibitory concentration: > 20000 nM
Compound 4: a limit, no number; the forecaster's own chance of this, stated with the estimate: 60%; the middle value lies on the limit itself.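

Compound 4, like compound 1 and compound 3, sits at a limit of the assay, and the steps among these three cannot be read. Open remains whether these three differ at all, and how far each lies from compound 2.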